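The compounds below may be only part of what the source reports. "The series", "measured", "known", "first", "only" and "open" are said of these compounds alone.

Compound 2 `CC(C)[C@H](NC(=O)COc1cccc2ccccc12)C(=O)N[C@@H](CC(=O)O)C(=O)COc1ccc(OC(F)(F)F)cc1` gives 29100 nM in a functional assay on Jurkat cells (Homo sapiens) (on this read-out lower numbers stand for stronger inhibition and higher numbers for weaker inhibition), and stands at the low end of the three measured numbers: it is separated from compound 1 `CC(C)[C@H](NC(=O)COc1cccc2ccccc12)C(=O)N[C@@H](CC(=O)O)C(=O)COc1ccc(-c2ccccc2)cc1`, which gives 87900 nM, by a 3.0-fold lower number from compound 1 to compound 2 (0.48 log units; beyond the scatter), whereas compound 3 `CC(C)[C@H](NC(=O)COc1cccc2ccccc12)C(=O)N[C@@H](CC(=O)O)C(=O)COc1ccc(F)cc1F`, which gives 33200 nM, lies within the scatter of it by a 1.1-fold higher number from compound 2 to compound 3 (0.06 log units; within the scatter). Compound 4 `CC(C)[C@H](NC(=O)COc1cccc2ccccc12)C(=O)N[C@@H](CC(=O)O)C(=O)COc1c(F)c(F)cc(F)c1F` differs from compound 2 in one place: 2,3,5,6-tetrafluorophenyl in place of 4-(trifluoromethoxy)phenyl on an oxygen on a saturated carbon. The bearing comparisons are the aryl swaps on the same oxygen, a 2.6-fold lower number from compound 1 to compound 3 (0.42 log units; beyond the scatter) and the flat a 1.1-fold higher number from compound 2 to compound 3 (0.06 log units; within the scatter); exchanging one substituted phenyl for another here has moved this assay modestly at most. Compound 4 is therefore expected to show no step beyond the scatter, a 1.0-fold higher number from compound 2 to compound 4 (0.01 log units; within the scatter), with an estimate of 30000 nM and a range of 12000 nM to 75000 nM.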

Compound 4, half-maximal inhibitory concentration: 4500 nM
Estimate against measurement, compound 4: 6.7-fold (0.82 log units) above; the measured number lies below the stated range.
By their numbers in this assay, from the lowest: compound 4; then compounds 2 and 3 (each within the scatter of the next); then compound 1.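

At this oxygen on a saturated carbon, the choice of aryl group matters more than the earlier swaps suggested: in this assay, 2,3,5,6-tetrafluorophenyl gives (a 6.5-fold lower number from compound 2 to compound 4 (0.81 log units; beyond the scatter)) and (a 7.4-fold lower number from compound 3 to compound 4 (0.87 log units; beyond the scatter)). Against 4-phenylphenyl, the step reaches (a 20-fold lower number from compound 1 to compound 4 (1.29 log units; beyond the scatter)), the only large step in the series. No measurement shown explains this stronger inhibition.

The compounds leave open whether the gain depends on this exact fluorine pattern, which pentafluorophenyl or unsubstituted phenyl on the same oxygen would test. They also leave open whether it survives with an amine nitrogen in place of that oxygen.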